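The source may hold more compounds than are shown below. What is called first, only, known or untested is meant among the compounds shown, and "the series" means these compounds.

Measured compounds in a functional assay on U-87MG ATCC cells (Homo sapiens) for cytotoxicity, read by MTT assay, with a stated time of 72 h; on this read-out higher numbers stand for weaker inhibition and lower numbers for stronger inhibition:

Compound 1 `CN(C)CCn1cnnc1-c1cc(Oc2ccc(NC(=O)N/N=C/c3ccccc3O[N+](=O)[O-])cc2F)ccn1` gives 7150 nM.
Compound 2 `CN(C)CCn1cnnc1-c1cc(Oc2ccc(NC(=O)N/N=C/c3c(Cl)cccc3Cl)cc2F)ccn1` gives a limit of the assay, > 100000 nM.
Compound 3 `Cn1ncnc1-c1cc(Oc2ccc(NC(=O)N/N=C/c3ccccc3)cc2F)ccn1` gives a limit of the assay, > 100000 nM.

Compound 3 thus stands at the edge of what this assay can report, and so does compound 2; only compound 1 yields a number (the limit of > 100000 nM in this assay, at which 2 of the 3 values shown sit).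

Compound 4 `Cn1cnnc1-c1cc(Oc2ccc(NC(=O)N/N=C/c3ccccc3)cc2F)ccn1` has the same atoms as compound 3, joined differently: 4-methyl-4H-1,2,4-triazol-3-yl in place of 1-methyl-1H-1,2,4-triazol-5-yl on an aromatic carbon. Going by the values given here, the only measured step, an at least 13-fold higher number from compound 1 to compound 2 (1.14 log units; beyond the scatter), concerns the aryl group on the hydrazone carbon, not the triazole, so it gives no direct guide to a change of the triazole alone. Among the compounds with values here, compound 1 and compound 3 differ in two places at once, so their values show only that a compound of this series can yield a number when the hydrazone aryl group and the triazole substituent are both different.

Within the data shown here, with compound 3 at a limit and no measured step on the triazole, the expected change is small: compound 4 is estimated at a number no higher from compound 3 to compound 4 (the limit leaves the size open), most likely again a limit. The estimate for compound 4 is 100000 nM, within 25000 nM to 300000 nM.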

Compound 4, half-maximal inhibitory concentration: 36300 nM
The estimate for compound 4 lay 2.8-fold (0.44 log units) above the measured number; the measured number falls inside the stated range.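

Going by these compounds alone, this step is the first to touch the triazole alone. In this assay, placing 4-methyl-4H-1,2,4-triazol-3-yl instead of 1-methyl-1H-1,2,4-triazol-5-yl on the aromatic carbon next to the ring nitrogen gives an at least 2.7-fold lower number from compound 3 to compound 4 (0.44 log units; beyond the scatter). The two groups have the same atoms and the same counted features, so this position responds to how the triazole is joined and not only to what it contains. The true size of the step stays open in one direction, since the value for compound 3 is a limit and not a number: the limit of > 100000 nM in this assay, at which 2 of the 4 values shown sit.

The compounds shown do not tell whether the same triazole change would have a similar effect with the 2-(nitrooxy)phenyl or 2,6-dichlorophenyl groups on the hydrazone carbon, or with the 2-(dimethylamino)ethyl chain in place of the methyl. They also leave open how this position would respond to an ethyl group or a primary amine on the triazole, and they do not explain why the way the ring is joined changes the read-out.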